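Para-fluorine on the benzoyl group of compound 2

The source may report more compounds than this note shows. Statements on the series, on what has been measured and on what is new or still open speak of the compounds shown alone.

Measured so far:
compound 1 `CCC(=O)N(C)c1ccc2[nH]c(-c3n[nH]c4ccccc34)cc2n1`, 33500 nM
compound 2 `CN(C(=O)c1ccccc1)c1ccc2[nH]c(-c3n[nH]c4ccccc34)cc2n1`, 12500 nM

Going by the values given here, in a functional assay on SMMC-7721 cells (Homo sapiens) for antiproliferative activity, read by MTT assay, with a stated time of 72 h (a higher number here means a weaker inhibitor, a lower number a stronger inhibitor), compound 2 stands lowest of the two numbers, its only neighbour being compound 1, which lies a 2.7-fold lower number from compound 1 to compound 2 (0.43 log units; beyond the scatter) higher. Compound 3 `CN(C(=O)c1ccc(F)cc1)c1ccc2[nH]c(-c3n[nH]c4ccccc34)cc2n1` carries fluoro in place of hydrogen on an aromatic carbon. Among the compounds with values here, no measured step touches this ring position; the single step known, from compound 1 to compound 2, changed the group on the carbonyl carbon itself and was modest. With nothing to rest on, the change is expected to move this assay by no more than the scatter, a 1.3-fold lower number from compound 2 to compound 3 (0.10 log units; within the scatter). Compound 3 is therefore estimated at 10000 nM, between 4000 nM and 25000 nM.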

Compound 3, half-maximal inhibitory concentration: 9150 nM
The estimate for compound 3 lay 1.1-fold (0.04 log units) above the measured number; low and high end bracket the measured number.
By their numbers in this assay, from the lowest: compounds 3 and 2 (each within the scatter of the next); then compound 1.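

In this assay, fluoro in place of hydrogen on this six-membered aromatic ring, para to a large group, gives a 1.4-fold lower number from compound 2 to compound 3 (0.14 log units; within the scatter) and so leaves the number at this position indistinguishable from that of the unsubstituted benzoyl compound. The step from ethyl on the carbonyl carbon survives with the 4-fluorophenyl group, which gives a 3.7-fold lower number from compound 1 to compound 3 (0.56 log units; beyond the scatter) and remains modest. No measurement offered here explains either result. As far as these compounds go, whether a larger group at this position, such as methoxy, trifluoromethyl or an amine, would move the number beyond the scatter remains open.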